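Triazole-linked benzo-fused core: sugar replaced by dihydroxypropyl

The source may report more compounds than this note shows. Statements on the series, on what has been measured and on what is new or still open speak of the compounds shown alone.

Measured compounds in a functional assay on SH-SY5Y cells (Homo sapiens) for cytotoxicity, read by MTT assay, with a stated time of 72 h; a higher number here means a weaker inhibitor, a lower number a stronger inhibitor:
compound 1 `CN1CCN(CCCCCCn2c3c(c4ccccc42)C(=O)c2c[n+]([O-])c4ccccc4c2C3=O)CC1` gives 920 nM
compound 2 `CN1CCN(CCCCCn2c3c(c4ccccc42)C(=O)c2c[n+]([O-])c4ccccc4c2C3=O)CC1` gives 830 nM
compound 3 `O=C1c2c[n+]([O-])c3ccccc3c2C(=O)c2c1c1ccccc1n2Cc1cn([C@H]2C[C@H](O)[C@@H](CO)O2)nn1` gives 620 nM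

Compound 3 sits at the low end of the three numbers, but its gap to compound 2 and its gap to compound 1 are both within the scatter, so no ordering among the three is supported. Going by the values given here, the only step between measured compounds is a 1.1-fold lower number from compound 1 to compound 2 (0.04 log units; within the scatter); it concerns the chain carrying the 4-methylpiperazin-1-yl group and does not touch the triazole substituent.

Compound 4 `O=C1c2c[n+]([O-])c3ccccc3c2C(=O)c2c1c1ccccc1n2Cc1cn(C[C@@H](O)CO)nn1` differs from compound 3 in one place: 2,3-dihydroxypropyl in place of 4-hydroxy-5-(hydroxymethyl)oxolan-2-yl on an aromatic nitrogen. Among the compounds with values here, no measured pair changes the group on the aromatic nitrogen of the triazole, so nothing directly bears on this step. Within the data shown here, the one step that exists, on the other side of the shared core, stayed within the scatter, and the three compounds span a narrow range. For compound 4 in this assay a step of a 1.1-fold higher number from compound 3 to compound 4 (0.05 log units; within the scatter) is therefore expected, which is no movement beyond the scatter. The estimate for compound 4 is 700 nM, with a range from 300 nM to 1600 nM.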

Compound 4, half-maximal inhibitory concentration: > 500 nM
Compound 4: no number, only a limit; the forecaster's own chance of this, stated with the estimate: 5%; the middle value lies beyond the limit too.
By their numbers in this assay, from the lowest: compounds 3, 2 and 1 (each within the scatter of the next).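

In this assay compound 4 gives > 500 nM, a limit and not a number. Going by these compounds alone, no step from compound 1, compound 2 or compound 3 to compound 4 can be read. Still open, on these data alone, is how 2,3-dihydroxypropyl compares with 4-hydroxy-5-(hydroxymethyl)oxolan-2-yl on the aromatic nitrogen.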